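Pyrrol-1-yl for thiophen-2-yl on the benzyl arm of compound 1

A few compounds are considered here, and "the series" means these few. Any claim that something is new, unique, unknown or untested is made for them only; others in the source may bear on it.

Compound 1 `O=C(Nc1c(F)cc(F)cc1F)N(Cc1ccc(-c2cccs2)cc1)C1CCCCCC1` carries a thiophen-2-yl group on its benzyl arm and a 2,4,6-trifluorophenyl on the urea nitrogen. In a functional assay on a cell-free system (plasma) with sterol O-acyltransferase, Soat (Rattus norvegicus) as the target (on this read-out higher numbers stand for an effect only at larger amounts of compound and lower numbers for an effect already at smaller amounts), compound 1 gives only a limit, > 1 mg/kg, not a number, which is the limit of > 1 mg/kg in this assay, at which 1 of the 2 values shown sits. Compound 2 `Cc1cc(C)c(NC(=O)N(Cc2ccc(-c3cccs3)cc2)C2CCCCCC2)c(C)c1` gives 0.28 mg/kg in this assay. Within the data shown here, the one measured step, an at least 3.5-fold lower number from compound 1 to compound 2 (0.55 log units; beyond the scatter), changes the aryl on the urea nitrogen and leaves the benzyl arm untouched, so it does not speak to the change considered here.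

Compound 3 `O=C(Nc1c(F)cc(F)cc1F)N(Cc1ccc(-n2cccc2)cc1)C1CCCCCC1` differs from compound 1 in 1H-pyrrol-1-yl in place of thiophen-2-yl on an aromatic carbon. Among the measured compounds shown here, no measured step covers this exchange, and the only anchor is the limit of compound 1. The step from compound 1 to compound 3 is therefore expected at a step that the limit leaves unreadable from compound 1 to compound 3, with no direction beyond the scatter that the data would support. Compound 3 is estimated at 2 mg/kg, within a range from 0.5 mg/kg to 10 mg/kg.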

Compound 3, dose for half-maximal effect: > 1 mg/kg
Compound 3 gave a limit, no number; the forecaster's own chance of this, stated with the estimate: 65%; the middle value does not contradict the limit.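

Compound 1 and compound 3 both give a limit, not a number, so no step can be read between them: the limit of > 1 mg/kg in this assay, at which 2 of the 3 values shown sit. The compounds shown leave open whether 1H-pyrrol-1-yl in place of thiophen-2-yl changes the dose for half-maximal effect at all.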